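Adding a 2-chlorophenyl group to a triazole anticonvulsant series

This account rests on a few compounds, and the source may have more. Where it says the series, first, only, none or still open, it means among the compounds named here.

Of the compounds shown here, three sharing one core have been tested in a functional assay on the whole organism (strain C57B/6) with Mus musculus as the target, in the maximal electroshock model; a lower number here means that less compound is needed, a higher number that more compound is needed for the effect. Compound 1 `CCCCCCOc1ccc(-n2cnnc2CC)cc1` gives 13.2 mg/kg. Compound 2 `CCCCCCOc1ccc(-n2cnnc2CCCC)cc1` gives 13.6 mg/kg, the second highest of the three numbers, though the step of a 1.0-fold higher number from compound 1 to compound 2 (0.01 log units; within the scatter) lies within the scatter. Compound 3 `CCCCCCOc1ccc(-n2cnnc2-c2ccccc2)cc1` gives 19 mg/kg, and the steps of a 1.4-fold higher number from compound 1 to compound 3 (0.16 log units; within the scatter) and a 1.4-fold higher number from compound 2 to compound 3 (0.15 log units; within the scatter) are also within the scatter, so none of the three can be called the most or least active.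

The next compound, compound 4 `CCCCCCOc1ccc(-n2cnnc2-c2ccccc2Cl)cc1`, differs from compound 2 in one place: 2-chlorophenyl in place of butyl on an aromatic carbon. The step that bears most on this change is a 1.4-fold higher number from compound 2 to compound 3 (0.15 log units; within the scatter), since there too a ring replaced the butyl chain on the same carbon of the core. That step was small, so for compound 4 no step beyond the scatter in either direction is expected in this assay. The estimated step of a 1.3-fold higher number from compound 2 to compound 4 (0.10 log units; within the scatter) is expected to be small. For compound 4 the dose for half-maximal effect is expected to be about 17 mg/kg, with a likely range from 8 mg/kg to 36 mg/kg.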

Compound 4, dose for half-maximal effect: 13.2 mg/kg
Compound 4: the middle estimate sits 1.3-fold (0.11 log units) above what was measured; measured number inside the range.
By their numbers in this assay, from the lowest: compounds 1, 4, 2 and 3 (each within the scatter of the next).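

Replacing a chain with a chlorinated ring at this position leaves the result in this assay within the scatter, with a 1.0-fold lower number from compound 2 to compound 4 (0.01 log units; within the scatter) for the butyl chain and no change at the digits printed from compound 1 to compound 4 (within the scatter) for the ethyl group. Adding chloro to the phenyl group gives a 1.4-fold lower number from compound 3 to compound 4 (0.16 log units; within the scatter) and is also within the scatter, so this carbon of the shared core has now carried ethyl, butyl, phenyl and 2-chlorophenyl without any step beyond the scatter. No measurement here explains why these four groups give such similar results.

On these data alone, whether this tolerance extends to an amine, a carboxylic acid or a chain longer than butyl on this carbon remains open. All four compounds also share the rest of the structure, so the contribution of that part to the dose needed cannot be read from them.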